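This account rests on a few compounds, and the source may have more. Where it says the series, first, only, none or still open, it means among the compounds named here.

Compounds measured in a functional assay on MCF7 cells (Homo sapiens) for cytotoxicity, read by neutral red uptake, with a stated time of 3 days; on this read-out higher numbers stand for weaker inhibition and lower numbers for stronger inhibition:

Compound 1, `Nc1ccc(-c2cc(=O)c3c(N)c(F)cc(F)c3o2)cc1F`, gives 40 nM.
Compound 2, `Nc1ccc(-c2cc(=O)c3c(N)c(F)c(C(=O)O)c(F)c3o2)cc1F`, gives only the limit of > 10000 nM in this assay.
Compound 3, `CCC(=O)OCc1c(F)c(N)c2c(=O)cc(-c3ccc(N)c(F)c3)oc2c1F`, gives 130 nM.

Compound 3 stands highest of the two numbers in this assay, its nearest neighbour being compound 1; the third value is a limit, as noted in the limit of > 10000 nM in this assay, at which 1 of the 3 values shown sits.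

Compound 4, `CN(C)CCC(=O)OCc1c(F)c(N)c2c(=O)cc(-c3ccc(N)c(F)c3)oc2c1F`, differs from compound 3 by dimethylamino in place of hydrogen on a saturated chain carbon, two bonds along the chain from a carbonyl carbon. The change sits out on the ester chain of the (propanoyloxy)methyl group, not on the aromatic carbon itself.

Going by the values given here, two measured steps bear on that position. Placing the (propanoyloxy)methyl group gave a 3.3-fold higher number from compound 1 to compound 3 (0.51 log units; beyond the scatter), whereas the carboxy group gave an at least 250-fold higher number from compound 1 to compound 2 (2.39 log units; beyond the scatter), and exchanging the two gave an at least 76-fold lower number from compound 2 to compound 3 (1.88 log units; beyond the scatter). Among the compounds with values here, the present change is smaller and further out than either, and no measured pair tests a dimethylamino group anywhere on these compounds. A step near or slightly beyond the scatter is therefore expected, with a higher number rather than a lower one as the more likely direction, so that compound 4 is estimated at a 1.7-fold higher number from compound 3 to compound 4 (0.23 log units; within the scatter). In this assay compound 4 is expected to give about 220 nM, within a range from 60 nM to 800 nM.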

Compound 4, half-maximal inhibitory concentration: 19 nM
For compound 4 the middle estimate is 12-fold (1.06 log units) above the measured one, and the stated range ends above it.
By their numbers in this assay, from the lowest: compound 4; then compound 1; then compound 3. At a limit, above all of these: compound 2.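

In this assay, going by these compounds alone, the step of a 6.8-fold lower number from compound 3 to compound 4 (0.84 log units; beyond the scatter) shows that the ester chain, untouched among the earlier compounds, is a place where dimethylamino in place of hydrogen on a saturated chain carbon moves the number beyond the scatter, and moves it down. The whole group also changes its standing against the hydrogen of the core: the step of a 3.3-fold higher number from compound 1 to compound 3 (0.51 log units; beyond the scatter) for (propanoyloxy)methyl is replaced by the step of a 2.1-fold lower number from compound 1 to compound 4 (0.32 log units; beyond the scatter) for the group that carries the dimethylamino. Compound 2 gives only a limit, so the step of an at least 520-fold lower number from compound 2 to compound 4 (2.72 log units; beyond the scatter) is a bound and not an exact size: the limit of > 10000 nM in this assay, at which 1 of the 4 values shown sits.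

A primary amine, a piperidine ring or a longer chain between the carbonyl and the nitrogen stands outside the compounds shown, so it remains open whether this step belongs to dimethylamino in particular or to any amine at this place. Equally open is whether the ester link itself matters, as an amide in its place is not among these compounds.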